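Two Receptor Ligands and an Untested Sulfur-Containing Analogue

The compounds below may be only part of what the source reports. "The series", "measured", "known", "first", "only" and "open" are said of these compounds alone.

Measured compounds:
compound 1, `CCCCCCCCC(O)/C=C/c1cccc(CC(O)c2cccc(C(=O)O)c2)n1`, 1 nM
compound 2, `CCCCCCCCCCCCOc1ccc(COc2cccc(C(=O)O)c2)nc1/C=C/C(=O)O`, 1130 nM

Both compounds were tested in an assay for binding affinity to leukotriene B4 receptor 1 (Homo sapiens); a higher number here means a weaker inhibitor, a lower number a stronger inhibitor. Of the two numbers, compound 2 has the higher one, so it is the weaker binder of the pair; compound 1 is far stronger, and the gap between them lies well beyond the usual scatter of repeated measurements.

Compound 3, `CCCCCCCCCCCCOc1ccc(C[S+]([O-])c2cccc(C(=O)O)c2)nc1/C=C/C(=O)O`, has not yet been measured. It differs from compound 2 in one place: a group of 11 heavy atoms (7 carbon, 3 oxygen, 1 sulfur; one six-membered aromatic ring of carbon only) in place of a group of 10 heavy atoms (7 carbon, 3 oxygen; one six-membered aromatic ring of carbon only), on a saturated chain carbon bound to an aromatic carbon. The change is a swap of the link between the shared core and the carboxyphenyl ring, keeping the same number of rings, double bonds, hydrogen-bond donors and acceptors, and adding a sulfur atom.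

Among the compounds with values here, no pair of measured compounds shows what such a swap does in this assay, so the direction of the step cannot be read from the data. The most cautious expectation is a step of modest size, within or near the scatter. Compound 3 is therefore expected to bind with an inhibition constant of about 900 nM, in a range from 250 nM to 3500 nM, which means an estimated step of a 1.3-fold lower number from compound 2 to compound 3 (0.10 log units; within the scatter).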

Compound 3, inhibition constant: 129 nM
Beside the measured number, compound 3's estimate is 7.0-fold (0.84 log units) above it, outside the stated range (below it).
By their numbers in this assay, from the lowest: compound 1; then compound 3; then compound 2.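

Swapping the 3-carboxyphenoxy group for the sulfur-containing group, on a saturated chain carbon bound to an aromatic carbon, gives an 8.8-fold lower number from compound 2 to compound 3 (0.94 log units; beyond the scatter) in this assay, so this position is sensitive to what links the shared core to the carboxyphenyl ring. The step is beyond the usual scatter even though the counted features stay the same in the group that leaves and the group that enters: one six-membered aromatic ring of carbon only, one double bond outside aromatic rings, the same hydrogen-bond donor and acceptor counts, and no net charge. Those counts therefore do not account for the difference, and no measurement at hand gives a reason for the step.

The compounds shown leave open whether the sulfur atom alone or the sulfur together with the oxygen attached to it is tied to the lower number. A plain thioether link, a sulfone link or an amine link at the same place would help to separate these possibilities, and a single step cannot show whether the same swap would do the same on another core.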